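This account rests on a few compounds, and the source may have more. Where it says the series, first, only, none or still open, it means among the compounds named here.

Compound 1 `COc1ccc(S(=O)(=O)N2CCc3cccc(-c4ccncc4)c32)cc1` gives 106 nM in a functional assay on KB-VIN10 cells (Homo sapiens) for inhibition, with a stated time of 72 h; on this read-out higher numbers stand for weaker inhibition and lower numbers for stronger inhibition.
Compound 2 `COc1ccc(S(=O)(=O)N2CCc3cccc(-c4cccs4)c32)cc1` gives 251 nM.
Compound 3 `COc1ccc(S(=O)(=O)N2CCc3cccc(-c4ccc(N)cc4)c32)cc1` gives 262 nM.

Where does compound 3 stand? Its number and that of compound 2 lie within the usual scatter of each other, so the two cannot be told apart; against compound 1 the gap is real, as the step of a 2.5-fold higher number from compound 1 to compound 3 (0.39 log units; beyond the scatter) shows.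

The next compound, compound 4 `COc1ccc(S(=O)(=O)N2CCc3cccc(-c4cccc(F)c4)c32)cc1`, has not yet been measured. It differs from compound 3 in one place: 3-fluorophenyl in place of 4-aminophenyl on an aromatic carbon.

The measured steps that bear on this all concern the aromatic group attached to the shared core. a 2.4-fold higher number from compound 1 to compound 2 (0.37 log units; beyond the scatter) and a 2.5-fold higher number from compound 1 to compound 3 (0.39 log units; beyond the scatter) are both modest losses against compound 1, while a 1.0-fold higher number from compound 2 to compound 3 (0.02 log units; within the scatter) shows no difference beyond the scatter. Going by the values given here, no measured compound carries a fluorine, and nothing here tells directly how a 3-fluorophenyl group behaves. Given that compound 1 gives 106 nM and compound 3 gives 262 nM, the whole measured range is modest, and compound 4 is expected to fall inside it. The expected step is a 1.3-fold lower number from compound 3 to compound 4 (0.12 log units; within the scatter), a slight move toward stronger inhibition that may not clear the scatter. Compound 4 is therefore estimated at 200 nM, with a range from 80 nM to 550 nM.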

Compound 4, half-maximal inhibitory concentration: 92.4 nM
Beside the measured number, compound 4's estimate is 2.2-fold (0.34 log units) above it; measured number inside the range.
By their numbers in this assay, from the lowest: compounds 4 and 1 (each within the scatter of the next); then compounds 2 and 3 (each within the scatter of the next).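

The change from an amine-bearing ring to a fluorine-bearing ring of the same size matters in this assay: it gives a 2.8-fold lower number from compound 3 to compound 4 (0.45 log units; beyond the scatter), so the group carried on a six-membered carbon ring can shift the result at this position, even with the heavy-atom count unchanged. The 3-fluorophenyl group also improves on thiophen-2-yl, with a 2.7-fold lower number from compound 2 to compound 4 (0.43 log units; beyond the scatter). Set against pyridin-4-yl, it gives a 1.1-fold lower number from compound 1 to compound 4 (0.06 log units; within the scatter), which shows that a ring made of carbon only can match the nitrogen-containing ring, so a ring nitrogen is not needed for the best numbers seen in this small set, and no measurement offered here explains these differences.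

The step from compound 3 to compound 4 changes both the identity of the group on the ring and its place, so the compounds shown cannot separate the loss of the amine from the arrival of the fluorine or from the move. A plain phenyl group, with neither amine nor fluorine, would help to divide these effects, and a chlorine or methoxy group in place of the fluorine would test whether fluorine itself is special.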